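A few compounds are considered here, and "the series" means these few. Any claim that something is new, unique, unknown or untested is made for them only; others in the source may bear on it.

Compound 1, `CCCc1cccc(C[C@H](O)/C=C/[C@H]2CCC(=S)N2CCCCCCC(=O)O)c1`, gives 6800 nM in an assay on CHO cells for displacement of a labelled ligand from prostaglandin E2 receptor EP2 subtype (Mus musculus), read by scintillation counting, with a stated time of 60 min; on this read-out higher numbers stand for weaker inhibition and lower numbers for stronger inhibition.
Compound 2, `O=C(O)CCCSCCN1C(=O)OC[C@@H]1/C=C/[C@@H](O)Cc1cccc(C(F)(F)F)c1`, gives > 10000 nM in this assay, which is a limit of the assay and not a number.
Compound 3, `O=C(O)CCCSCCN1C(=O)SC[C@@H]1/C=C/[C@@H](O)Cc1ccccc1`, gives > 10000 nM in this assay, again only a limit.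

Compound 2 therefore stands at the edge of what this assay can report, and it shares that position with one other compound: the limit of > 10000 nM in this assay, at which 2 of the 3 values shown sit. Among the compounds with values here, the only value that is a number belongs to compound 1, which carries a propyl group on its aromatic ring and a different core.

Compound 4 is `CCc1cccc(C[C@H](O)/C=C/[C@H]2COC(=O)N2CCSCCCC(=O)O)c1`. It differs from compound 2 in one place: ethyl in place of trifluoromethyl on an aromatic carbon. Within the data shown here, no two measured compounds differ from each other in a single place, so no measured step shows what this exchange does on its own. Compound 1 and compound 3 carry different cores and different aromatic substituents, and their values do not isolate the aryl change.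

The step of a number no higher from compound 2 to compound 4 (the limit leaves the size open) is expected to be small, not beyond the usual scatter, and its direction is uncertain. Compound 4 is expected to give 10000 nM, in a range from 3000 nM to 30000 nM, with a real chance that this assay reports only a limit for it.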

Compound 4, inhibition constant: > 10000 nM
Compound 4 ended at the assay's limit; the forecaster's own chance of this, stated with the estimate: 55%; the middle value sits exactly at the limit.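

Compound 2 and compound 4 both sit at a limit of this assay, not at a number, so no step can be read between them: the limit of > 10000 nM in this assay, at which 3 of the 4 values shown sit. The compounds shown leave open what the exchange of trifluoromethyl for ethyl does on its own, and how far past the limit compound 2 and compound 4 lie.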